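Swapping a Sulfonamide Arm for a Nonyl Chain

A few compounds are considered here, and "the series" means these few. Any claim that something is new, unique, unknown or untested is made for them only; others in the source may bear on it.

Measured so far:
compound 1, `O=C1O[C@H]([C@@H](O)Cn2cc(CNS(=O)(=O)c3ccc(Cl)cc3F)nn2)C(OCc2ccccc2)=C1OCc1ccccc1`, 39100 nM
compound 2, `O=C1O[C@H]([C@@H](O)Cn2cc(-c3cc(C(F)(F)F)cc(C(F)(F)F)c3)nn2)C(OCc2ccccc2)=C1OCc1ccccc1`, 28900 nM

Both numbers come from a functional assay on A549 cells (Homo sapiens) for antiproliferative activity, read by MTT assay, with a stated time of 72 h; on this read-out lower numbers stand for stronger inhibition and higher numbers for weaker inhibition. Compound 1 shows the higher of the two numbers, but its gap to compound 2 lies within the scatter, so the two compounds cannot be told apart on this read-out.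

The next compound, compound 3 with structure `CCCCCCCCCCc1cn(C[C@H](O)[C@H]2OC(=O)C(OCc3ccccc3)=C2OCc2ccccc2)nn1`, keeps the shared core of compound 1 and changes one group: nonyl in place of ((4-chloro-2-fluorophenyl)sulfonyl)amino on a saturated chain carbon bound to an aromatic carbon. A sulfonamide-bearing aryl arm with one hydrogen-bond donor and two acceptors gives way to a plain nine-carbon chain without rings or donors.

Within the data shown here, no measured pair shows a change of this kind, so the size of the step is uncertain. A moderate shift toward a lower number in this assay, somewhat beyond the scatter, is expected for a 2.6-fold lower number from compound 1 to compound 3 (0.42 log units; beyond the scatter). Compound 3 is therefore estimated at 15000 nM, with a likely range from 4000 nM to 50000 nM.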

Compound 3, half-maximal inhibitory concentration: 6750 nM
Compound 3: middle estimate off by 2.2-fold (0.35 log units), on the high side; measured number inside the range.
By their numbers in this assay, from the lowest: compound 3; then compounds 2 and 1 (each within the scatter of the next).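

Among these compounds, this is the first step that can be read at this position. In this assay, with the shared core held fixed, nonyl in place of ((4-chloro-2-fluorophenyl)sulfonyl)amino on a saturated chain carbon bound to an aromatic carbon gives a 5.8-fold lower number from compound 1 to compound 3 (0.76 log units; beyond the scatter). The number in this assay therefore does not need the departing arm's aromatic ring or its hydrogen-bond donor, since a chain with no ring, 0 hydrogen-bond donors and 0 hydrogen-bond acceptors gives the lower value. Nothing measured alongside these compounds points to a cause for the shift.

Going by these compounds, it remains open whether the lower number comes from gaining the nonyl chain or from losing the sulfonamide arm. A butyl or dodecyl chain, or a nonyl chain ending in an amine or a carboxylic acid, would help separate the two.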